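The compounds below may be only part of what the source reports. "The series", "measured", "known", "first", "only" and "open" are said of these compounds alone.

Measured so far:
compound 1, `Cc1noc(-c2nc(C)c3c(c2N)C(=O)N(Cc2ccc(Br)cc2)C3=O)n1`, in a physicochemical assay for solubility, using the shake flask method, in simulated intestinal fluid, measured as kinetic solubility, with a stated time of 2 h, at 25 degrees C, at pH 6.5 (on this read-out lower numbers stand for lower solubility and higher numbers for higher solubility), gives < 5000 nM
compound 2, `Cc1noc(-c2nc(C)c3c(c2N)C(=O)N(C(C)c2ccccc2)C3=O)n1`, in this assay gives 10900 nM

Among the compounds with values here, compound 2 holds the only plain number in this assay, standing at 10900 nM. For compound 1 the read-out is only a limit of the assay and not a number. Compound 3, `Cc1noc(-c2nc(C)c3c(c2N)C(=O)N(Cc2ccc(CO)cc2)C3=O)n1`, has not yet been measured. It differs from compound 2 in one place: 4-(hydroxymethyl)benzyl in place of 1-phenylethyl on an amide-type nitrogen in a ring. Within the data shown here, one measured step bears on this position, an at least 2.1-fold higher number from compound 1 to compound 2 (0.33 log units; beyond the scatter), and it shows that the group on the amide-type nitrogen in a ring can move the number beyond the scatter; because the limit of < 5000 nM in this assay, at which 1 of the 2 values shown sits, the true size of that step is known only as a floor. On the strength of that single comparison, an upward step of a 1.8-fold higher number from compound 2 to compound 3 (0.26 log units; within the scatter) is expected for compound 3. The estimate for compound 3 in this assay is 20000 nM, with a range from 8000 nM to 60000 nM.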

Compound 3, solubility: < 5000 nM
Compound 3 gave a limit, no number; the forecaster's own chance of this, stated with the estimate: 15%; middle value at least 4.0-fold (0.60 log units) from the limit.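

In this assay, the group on the amide-type nitrogen in a ring can now be seen to move the number down as well as up: 4-(hydroxymethyl)benzyl in place of 1-phenylethyl gives an at least 2.1-fold lower number from compound 2 to compound 3 (0.33 log units; beyond the scatter). The entering group brings a hydrogen-bond donor and a hydrogen-bond acceptor, yet compound 3 gives < 5000 nM, which is a limit of the assay and not a number. The size of this step is known only as a floor, and the step that swaps bromo for hydroxymethyl cannot be read at all, because both ends of it sit at one limit: the limit of < 5000 nM in this assay, at which 2 of the 3 values shown sit.

Still open, on these data alone, is whether any benzyl group on this nitrogen would land at that limit, or whether 1-phenylethyl is itself what matters. A plain benzyl group, or a benzyl carrying an amine or a carboxylic acid, would help to separate these possibilities.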